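From methyl to cyclopropylmethyl on a shared core

The compounds below may be only part of what the source reports. "The series", "measured", "known", "first", "only" and "open" are said of these compounds alone.

compound 1 `CC(C)c1nc2cc(Cl)c(Cl)cc2[nH]1`: 52000 nM
compound 2 `OC[C@H]1O[C@@H](n2cnc3cc(F)c(F)cc32)[C@H](O)[C@@H]1O`: 67000 nM
compound 3 `Cn1c(C(F)(F)F)nc2cc(Cl)c(Cl)cc21`: 56000 nM

All of these values come from a functional assay on HCT-116 cells (Homo sapiens) for cytotoxicity, read by MTT assay, with a stated time of 48 h; a lower number here means a stronger inhibitor of growth, a higher number a weaker inhibitor of growth. Compound 3, at 56000 nM, cannot be told apart from compound 1 or compound 2, since its gaps to both lie within the usual scatter.

The next compound is compound 4 `FC(F)(F)c1nc2cc(Cl)c(Cl)cc2n1CC1CC1`, which differs from compound 3 in one place: cyclopropyl in place of hydrogen on a saturated chain carbon bound to an aromatic nitrogen. Here cyclopropyl stands in place of hydrogen on a saturated chain carbon bound to an aromatic nitrogen, so methyl becomes cyclopropylmethyl.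

Within the data shown here, no measured pair differs in just one place, so the data do not show what a single change does here. Still, compound 1 at 52000 nM and compound 2 at 67000 nM differ from compound 3 in more than one place and remain within the scatter of it. A step beyond the scatter is therefore not expected, with only a slight lean toward a lower number. The estimated step is a 1.2-fold lower number from compound 3 to compound 4 (0.09 log units; within the scatter). For compound 4 the estimate is 45000 nM, with an expected range of 20000 nM to 90000 nM.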

Compound 4, concentration for 50% growth inhibition: 61300 nM
The estimate for compound 4 lay 1.4-fold (0.13 log units) below the measured number; the measured number falls inside the stated range.
By their numbers in this assay, from the lowest: compounds 1, 3, 4 and 2 (each within the scatter of the next).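

Among these compounds, this is the first pair here that differs in one place only, so it gives the first direct reading of a change at this position. In this assay cyclopropyl in place of hydrogen on a saturated chain carbon bound to an aromatic nitrogen gives a 1.1-fold higher number from compound 3 to compound 4 (0.04 log units; within the scatter) and so no difference that can be told from the scatter: methyl can become cyclopropylmethyl, adding a ring, without a detectable gain or loss in growth inhibition. No measurement is available that would explain this result.

The compounds shown leave open whether a different kind of group at this place, such as an amine or a carboxylic acid, would move the number beyond the scatter. They also leave open whether a longer chain ending in a hydroxyl group would do so.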